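The compounds below may be only part of what the source reports. "The series", "measured", "known", "first", "only" and "open" are said of these compounds alone.

Three compounds that share one core have numbers in a functional assay on V79 cells (Cricetulus griseus) for cytotoxicity, read by colony formation; on this read-out higher numbers stand for weaker inhibition and lower numbers for stronger inhibition. Compound 3 `COc1c(N2CCNCC2)c(F)cc2c(=O)c(C(=O)O)cn(C3CC3)c12` gives 82 ug/mL, the highest number of the three. Compound 2 `COc1c(N2CCC(C)(CN)C2)c(F)cc2c(=O)c(C(=O)O)cn(C3CC3)c12` gives 38 ug/mL, and compound 1 `CCNCC1CCN(c2c(F)cc3c(=O)c(C(=O)O)cn(C4CC4)c3c2OC)C1` gives 22 ug/mL; 22 ug/mL (2 entries).

The next compound to consider is compound 4 `COc1c(N2CCC(C)(N)C2)c(F)cc2c(=O)c(C(=O)O)cn(C3CC3)c12`, where 3-amino-3-methylpyrrolidin-1-yl stands in place of piperazin-1-yl on an aromatic carbon: 3-amino-3-methylpyrrolidin-1-yl in place of piperazin-1-yl on an aromatic carbon. Within the data shown here, the one measured step that bears on this change is a 2.2-fold higher number from compound 2 to compound 3 (0.33 log units; beyond the scatter), with piperazin-1-yl in place of 3-(aminomethyl)-3-methylpyrrolidin-1-yl. That step is modest. Read in reverse, it leads to the expectation of a similarly modest fall in the number in this assay on leaving piperazin-1-yl, although the entering group here is not the one carried by compound 2, so the range must stay wide. The expected change is a 2.3-fold lower number from compound 3 to compound 4 (0.37 log units; beyond the scatter). Compound 4 is estimated at 35 ug/mL, with an expected range from 15 ug/mL to 80 ug/mL.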

Compound 4, half-maximal inhibitory concentration: 38 ug/mL
The estimate for compound 4 lay 1.1-fold (0.04 log units) below the measured number; the range from low to high includes it.
By their numbers in this assay, from the lowest: compounds 2 and 4 (each within the scatter of the next); then compound 3.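

Swapping piperazin-1-yl for 3-amino-3-methylpyrrolidin-1-yl on this aromatic carbon gives a 2.2-fold lower number from compound 3 to compound 4 (0.33 log units; beyond the scatter) in this assay, so a second substituted pyrrolidine, and not only the group on compound 2, now stands apart from piperazin-1-yl on this read-out. Amino in place of aminomethyl on the saturated ring carbon gives no change at the digits printed from compound 2 to compound 4 (within the scatter), so shortening that side arm leaves the number where it was. Nothing shown here explains either step.

On these data alone, the role of the methyl on that saturated ring carbon remains open, and a plain 3-aminopyrrolidin-1-yl group would separate it from the ring change. As far as these compounds go, whether the piperazine side can be shifted as well also remains open, and a 4-methylpiperazin-1-yl group would be one test of that.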